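The source may hold more compounds than are shown below. What is called first, only, known or untested is meant among the compounds shown, and "the series" means these compounds.

Measured so far:
- Compound 1 `O=C(Nc1cccc(-c2oc3cc(-c4ccc(F)cc4)ccc3c(=O)c2O)c1)c1ccc(Br)cc1`: 24000 nM
- Compound 2 `COc1cccc(C(=O)Nc2cccc(-c3oc4cc(-c5ccc(F)cc5)ccc4c(=O)c3O)c2)c1`: 15300 nM

Both numbers come from a functional assay on MCF7 cells (Homo sapiens) for antiproliferative activity, read by CCK-8 assay, with a stated time of 72 h; on this read-out lower numbers stand for stronger inhibition and higher numbers for weaker inhibition. Compound 1 and compound 2 share one core and differ only in the aromatic ring attached to the carbonyl carbon of the amide. Among the measured compounds shown here, the one measured step, a 1.6-fold lower number from compound 1 to compound 2 (0.20 log units; within the scatter), is within the scatter, so the two values cannot be ranked against each other. Compound 2 has the lowest of the two numbers, but its nearest neighbour, compound 1, sits within the scatter of it.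

Compound 3 `CCCc1ccc(C(=O)Nc2cccc(-c3oc4cc(-c5ccc(F)cc5)ccc4c(=O)c3O)c2)cc1` is not yet measured. Its change from compound 2 is 4-propylphenyl in place of 3-methoxyphenyl on a carbonyl carbon. For the measured compounds named here, no measured step involves a 4-propylphenyl group here; the only step available, from compound 1 to compound 2, changed the same ring and stayed within the scatter. On that basis no step beyond the scatter is expected in this assay, and compound 3 is estimated at 17000 nM, with a range from 6000 nM to 45000 nM, meaning an expected step of a 1.1-fold higher number from compound 2 to compound 3 (0.05 log units; within the scatter).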

Compound 3, half-maximal inhibitory concentration: 36800 nM
For compound 3 the middle estimate is 2.2-fold (0.34 log units) below the measured one, within the range that was stated.
By their numbers in this assay, from the lowest: compounds 2, 1 and 3 (each within the scatter of the next, the first and the last beyond it).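

In this assay the ring on the amide carbonyl now yields its first step beyond the scatter: 4-propylphenyl in place of 3-methoxyphenyl gives a 2.4-fold higher number from compound 2 to compound 3 (0.38 log units; beyond the scatter) and this step is modest. Propyl in place of bromo on an aromatic carbon gives a 1.5-fold higher number from compound 1 to compound 3 (0.19 log units; within the scatter) and stays within the scatter, so these two groups cannot be ranked against each other in this series. No supporting data explain either step.

The step to compound 3 swaps both the group and the number in its name. A 4-methoxyphenyl or a 3-propylphenyl ring would be needed to tell which of the two matters. Also open, on these data alone, is how this ring would respond to an amine, a carboxylic acid or a chain longer than propyl.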